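The source may hold more compounds than are shown below. What is called first, only, known or untested is meant among the compounds shown, and "the series" means these compounds.

Working notes on the series built on the core of compound 1 `O=C(Nc1ccc2[nH]c(=O)oc2c1)C(=O)N1CCN(c2ccc(Cl)cc2)CC1`, followed in an ADME assay on the whole organism (Rattus norvegicus, strain Sprague-Dawley) for pharmacokinetics, using cassette dosing, at a dose of 0.5 mg/kg by the intravenous route; on this read-out higher numbers stand for fast clearance and lower numbers for slow clearance. Compound 1 gives 7.2 mL/min/kg, compound 2 `O=C(Nc1ccc2[nH]c(=O)oc2c1)C(=O)N1CCN(c2ccc(F)cc2)CC1` gives 11.1 mL/min/kg, and compound 3 `O=C(Nc1ccc2[nH]c(=O)oc2c1)C(=O)N1CCN(c2ccc(F)c(F)c2)CC1` gives 4 mL/min/kg. Compound 3 separates clearly only from compound 2, with a 2.8-fold lower number from compound 2 to compound 3 (0.44 log units; beyond the scatter). Against compound 1 it shows a 1.8-fold lower number from compound 1 to compound 3 (0.26 log units; within the scatter).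

The next structure is compound 4 `O=C(Nc1ccc2[nH]c(=O)oc2c1)C(=O)N1CCN(c2ccc(F)c(Cl)c2)CC1`, with the change chloro in place of fluoro on an aromatic carbon, 3,4-difluorophenyl to 3-chloro-4-fluorophenyl. Among the compounds with values here, the nearest precedent exchanges the same two halogens in the opposite sense, and that step, a 1.5-fold higher number from compound 1 to compound 2 (0.19 log units; within the scatter), stays small. The larger step, a 2.8-fold lower number from compound 2 to compound 3 (0.44 log units; beyond the scatter), replaces hydrogen rather than one halogen with another, so it bears on this change only loosely. Compound 4 also keeps a halogen at the changed place. No step beyond the scatter is therefore expected in this assay, with at most a slight rise. The expected step is a 1.3-fold higher number from compound 3 to compound 4 (0.10 log units; within the scatter). The estimate for compound 4 is 5 mL/min/kg, within an expected range of 2.5 mL/min/kg to 10 mL/min/kg.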

Compound 4, clearance: 18.3 mL/min/kg
For compound 4 the middle estimate is 3.7-fold (0.56 log units) below the measured one; the measured number lies above the stated range.
By their numbers in this assay, from the lowest: compounds 3, 1, 2 and 4 (each within the scatter of the next, the first and the last beyond it).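

Chloro in place of fluoro at this place, ortho to a fluoro group, is not the small exchange that compound 1 and compound 2 suggested, giving a 4.6-fold higher number from compound 3 to compound 4 (0.66 log units; beyond the scatter) and showing that the exchange of these two halogens does not carry over between the two settings in this assay: the same change on two cores in this assay, a 1.5-fold higher number (0.19 log units; within the scatter) from compound 1 to compound 2 and a 4.6-fold lower number (0.66 log units; beyond the scatter) from compound 4 to compound 3, 7.1-fold (0.85 log units) apart, beyond the scatter of two such steps Chloro in place of hydrogen at this place gives a 1.6-fold higher number from compound 2 to compound 4 (0.22 log units; within the scatter), whereas fluoro in place of hydrogen gives a 2.8-fold lower number from compound 2 to compound 3 (0.44 log units; beyond the scatter), so of the two halogens only fluoro separates from hydrogen here. Against the 4-chlorophenyl group of compound 1, the 3-chloro-4-fluorophenyl group gives a 2.5-fold higher number from compound 1 to compound 4 (0.41 log units; beyond the scatter).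

Open, from the compounds shown here alone, is how a methyl, methoxy or nitrile group at this place would compare with fluoro and chloro in this assay. Also open, going by these compounds, is how a 3,4-dichlorophenyl group would stand against compound 1 and compound 4.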